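A few compounds are considered here, and "the series" means these few. Any claim that something is new, unique, unknown or untested is made for them only; others in the source may bear on it.

Measured so far:
Compound 1, `Cc1ccc(-n2nncc2CN2C(=O)C3(C(C#N)=C(N)Oc4c(N)cc5nc6ccccc6nc5c43)c3ccccc32)cc1C`, gives > 50000 nM in a functional assay on A549 cells (Homo sapiens) for antiproliferative activity, read by MTT assay, with a stated time of 48 h (on this read-out higher numbers stand for weaker inhibition and lower numbers for stronger inhibition), which is a limit of the assay and not a number.
Compound 2, `Cc1cc(C)cc(-n2nncc2CN2C(=O)C3(C(C#N)=C(N)Oc4c(N)cc5nc6ccccc6nc5c43)c3ccccc32)c1`, gives 31200 nM in this assay.

Compound 2 thus holds the only number shown in this assay; the other value recorded is a limit (the limit of > 50000 nM in this assay, at which 1 of the 2 values shown sits). For the measured compounds named here, the step of an at least 1.6-fold lower number from compound 1 to compound 2 (0.20 log units; that floor lies within the scatter) is the sole measured step, and its floor does not leave the scatter. Compound 3, `Cc1ccc(Cl)cc1-n1nncc1CN1C(=O)C2(C(C#N)=C(N)Oc3c(N)cc4nc5ccccc5nc4c32)c2ccccc21`, differs from compound 2 as follows: 5-chloro-2-methylphenyl in place of 3,5-dimethylphenyl on an aromatic nitrogen. Going by the values given here, no measured step exchanges the substituent on this aromatic nitrogen in a way that moved the number beyond the scatter, so nothing in the data points to a step in either direction. A step of a 1.1-fold higher number from compound 2 to compound 3 (0.05 log units; within the scatter) is expected, which stays within the scatter. Compound 3 is estimated at 35000 nM in this assay, with a range from 15000 nM to 80000 nM, and a fair chance that only a limit is reported.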

Compound 3, half-maximal inhibitory concentration: > 50000 nM
Compound 3 ended at the assay's limit; the forecaster's own chance of this, stated with the estimate: 40%; middle value at least 1.4-fold (0.15 log units) from the limit.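

Exchanging 3,5-dimethylphenyl for 5-chloro-2-methylphenyl on the aromatic nitrogen gives an at least 1.6-fold higher number from compound 2 to compound 3 (0.20 log units; that floor lies within the scatter) in this assay, so this second exchange at the position also has a floor that does not leave the scatter. Compound 3 gives > 50000 nM, which is a limit of the assay and not a number. The step between compound 1 and compound 3 cannot be read, and among the three aryl groups at this position only compound 2 has a number: the limit of > 50000 nM in this assay, at which 2 of the 3 values shown sit.

Whether the chlorine or the shifted methyl accounts for the return to the limit stays open, as both change in this one exchange. Also open, from the compounds shown here alone, is how the series responds to a group of another kind on this nitrogen, such as an unsubstituted phenyl, a methoxyphenyl, a pyridyl or a benzyl.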